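Thiophen-3-yl in Place of 3-Fluorophenyl

The compounds below may be only part of what the source reports. "The series", "measured", "known", "first", "only" and "open" are said of these compounds alone.

In a functional assay on G-361 cells (Homo sapiens) for inhibition, with a stated time of 72 h (a higher number here means a weaker inhibitor, a lower number a stronger inhibitor), compound 1 (`NC1CCC(Nc2nc(NCc3ccc(-c4ccccc4)cc3)c3ncn(C4CCCC4)c3n2)CC1`) gives 1020 nM. Compound 2 (`NC1CCC(Nc2nc(NCc3ccc(-c4cccc(F)c4)nc3)c3ncn(C4CCCC4)c3n2)CC1`) gives 49 nM, the lower of the two numbers, and the gap between them lies beyond the scatter. Compound 3 (`NC1CCC(Nc2nc(NCc3ccc(-c4ccsc4)nc3)c3ncn(C4CCCC4)c3n2)CC1`) has thiophen-3-yl in place of 3-fluorophenyl on an aromatic carbon. Within the data shown here, no measured pair of compounds shows this exchange, so the expectation rests on compound 2 alone. The expected step in this assay is a 1.2-fold higher number from compound 2 to compound 3 (0.09 log units; within the scatter), a slight rise that would stay within the scatter. For compound 3 the estimated value is 60 nM, with an expected range of 20 nM to 180 nM.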

Compound 3, half-maximal inhibitory concentration: 272 nM
Compound 3: the middle estimate sits 4.5-fold (0.66 log units) below what was measured; measured number outside the range, above it.
By their numbers in this assay, from the lowest: compound 2; then compound 3; then compound 1.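

In this assay the group next to the ring nitrogen proves sensitive to exchange: thiophen-3-yl in place of 3-fluorophenyl gives a 5.6-fold higher number from compound 2 to compound 3 (0.74 log units; beyond the scatter) and so loses much of the gain seen with compound 2. Even so, 6-(thiophen-3-yl)pyridin-3-yl in place of 4-phenylphenyl gives a 3.8-fold lower number from compound 1 to compound 3 (0.57 log units; beyond the scatter) and remains the better of that pair. Nothing available explains the loss at this position.
The compounds shown leave open whether an unsubstituted phenyl, thiophen-2-yl or 4-fluorophenyl at this place would match 3-fluorophenyl.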